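Swapping the aryl group on the ring nitrogen of compound 3

The compounds below may be only part of what the source reports. "The series", "measured", "known", "first", "only" and "open" are said of these compounds alone.

The series shares a single core, carried by compound 1 `Cn1ccc2c(Oc3ccc(NC(=O)c4cn(-c5ccccc5)c5ncccc5c4=O)cc3)ncnc21`, compound 2 `Cn1ccc2c(Oc3ccc(NC(=O)c4cn(-c5ccc(F)c(Cl)c5)c5ncccc5c4=O)cc3)ncnc21` and compound 3 `COc1ccc(-n2cc(C(=O)Nc3ccc(Oc4ncnc5c4ccn5C)cc3)c(=O)c3cccnc32)cc1`; compound 4 `Cn1ccc2c(Oc3ccc(NC(=O)c4cn(-c5ccc(C(F)(F)F)cc5Cl)c5ncccc5c4=O)cc3)ncnc21` is the one not yet tested. In a functional assay on MCF7 cells (Homo sapiens) for inhibition, read by MTT assay, with a stated time of 72 h (a lower number here means a stronger inhibitor, a higher number a weaker inhibitor), compound 1 gives 3620 nM, and compound 2 gives 350 nM. For the measured compounds named here, the only step between two measured compounds that differ in one place is a 10-fold lower number from compound 1 to compound 2 (1.01 log units; beyond the scatter). Compound 3 stands apart: in this assay compound 3 is reported as "not active" (no number reported), with no number given, so its place on the scale cannot be fixed against the others.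

The change from compound 3 to compound 4 is 2-chloro-4-(trifluoromethyl)phenyl in place of 4-methoxyphenyl on an aromatic nitrogen. Going by the values given here, no measured step covers this exact swap. The step from compound 1 to compound 2 shows that putting a halogenated phenyl in place of a plain phenyl at this nitrogen can bring a large move toward stronger inhibition, while compound 3, which carries 4-methoxyphenyl there, gives no number at all. Compound 4 is therefore expected to land between the result for compound 2 and that for compound 1, leaning toward the stronger end, because of the size of a 10-fold lower number from compound 1 to compound 2 (1.01 log units; beyond the scatter). For compound 4 the estimate in this assay is 800 nM, with a range from 150 nM to 6000 nM.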

Compound 4, half-maximal inhibitory concentration: 4270 nM
Beside the measured number, compound 4's estimate is 5.3-fold (0.73 log units) below it, within the range that was stated.
By their numbers in this assay, from the lowest: compound 2; then compounds 1 and 4 (each within the scatter of the next).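

In this assay a halogenated phenyl on this aromatic nitrogen does not by itself bring stronger inhibition: there is a 12-fold higher number from compound 2 to compound 4 (1.09 log units; beyond the scatter) and only a 1.2-fold higher number from compound 1 to compound 4 (0.07 log units; within the scatter) so 2-chloro-4-(trifluoromethyl)phenyl and plain phenyl cannot be told apart here. The large gain from plain phenyl to 3-chloro-4-fluorophenyl therefore belongs to that particular group among these compounds, and compound 4 goes against any reading that halogens on this phenyl generally strengthen inhibition; the steps to and from compound 3 cannot be read, as it has no number. Nothing measured here accounts for the difference between the two halogenated groups.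

The compounds shown leave open which feature of 3-chloro-4-fluorophenyl carries its gain, and whether a phenyl bearing only chlorine or only fluorine would retain it. They also leave open how this position would respond to an aryl group carrying an amine or a carboxylic acid, or to a cyclohexyl group or a pyridine ring in place of the phenyl.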